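Acylating the Ring Amine: From Compound 2 to Compound 4

A few compounds are considered here, and "the series" means these few. Any claim that something is new, unique, unknown or untested is made for them only; others in the source may bear on it.

Measured so far:
Compound 1 `Cc1ccc(N2CCN(C(=O)[C@@H]3CN(C4CCOCC4)C[C@H]3c3ccc(Cl)cc3)CC2)c([C@@H](NC(=O)[C@@H](C)N)C(C)C)c1`: in a functional assay on CHO cells with Melanocortin receptor 4 (Homo sapiens) as the target, read by cAMP accumulation (a higher number here means a larger maximal response, a lower number a smaller maximal response), compound 1 gives 56%.
Compound 2 `Cc1ccc(N2CCN(C(=O)[C@@H]3CNC[C@H]3c3ccc(Cl)cc3)CC2)c([C@@H](NC(=O)CCN(C)C)C(C)C)c1`: in this assay compound 2 gives 72%.
Compound 3 `Cc1ccc(N2CCN(C(=O)[C@@H]3CN(C4CCOCC4)C[C@H]3c3ccc(Cl)cc3)CC2)c([C@@H](NC(=O)[C@H](C)N)C(C)C)c1`: in this assay compound 3 gives 38%.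

Compound 2 stands highest of the three in this assay, with compound 1 nearest and compound 3 furthest. Within the data shown here, the only step within a single change is a number 18 percentage points lower from compound 1 to compound 3 (beyond the scatter), and it rests on the fact that compounds 1 and 3 differ only in the configuration as drawn: the two compounds share every atom and bond and differ only in how one stereocentre is drawn.

Compound 4 `CCC(=O)N1C[C@@H](C(=O)N2CCN(c3ccc(C)cc3[C@@H](NC(=O)CCN(C)C)C(C)C)CC2)[C@H](c2ccc(Cl)cc2)C1` differs from compound 2 in one place: propanoyl in place of hydrogen on an amine nitrogen in a ring. Among the measured compounds shown here, no measured step bears on this kind of change; compounds 1 and 3 carry a different group on that ring nitrogen and also differ from compound 2 elsewhere, so their values show only that a substituted ring nitrogen can go with either a smaller or a middling response. The expected step is therefore small and uncertain, a number 10 percentage points lower from compound 2 to compound 4 (within the scatter), with wide room either way. Compound 4 is estimated at 62%, between 40% and 84%.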

Compound 4, intrinsic activity: the largest response reached, in percent of the reference agonist's: 129%
Compound 4: the middle estimate sits 67 percentage points below what was measured; the measured number lies above the stated range.
By their numbers in this assay, from the lowest: compound 3; then compound 1; then compound 2; then compound 4.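

Putting propanoyl in place of hydrogen on this ring nitrogen gives, in this assay, a number 57 percentage points higher from compound 2 to compound 4 (beyond the scatter), so with the rest of the molecule unchanged, the group on this nitrogen can greatly change the maximal response. The change also crosses a notable line: compound 2 gives 72%, short of the reference agonist's maximal response, whereas compound 4 gives 129%, beyond it. Nothing measured among these compounds bears on why this step is so large.

On these data alone, whether the gain needs the carbonyl or only the carbon chain stays open, and a propyl group on the same nitrogen, which has the chain without the carbonyl, would separate the two. So would a shorter acetyl group or a longer butanoyl chain, which would show how far the response depends on the length of the acyl group.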